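Compound 2 to compound 3: exchanging the 4-ethylphenyl

A few compounds are considered here, and "the series" means these few. Any claim that something is new, unique, unknown or untested is made for them only; others in the source may bear on it.

In an ADME assay on PBMC cells (Homo sapiens) for cytotoxicity, read by MTT assay, with a stated time of 72 h, in the absence of a further agent (a lower number here means a stronger inhibitor, a higher number a weaker inhibitor), compound 1 (`COc1ccc(Nc2ccc3ccccc3n2)cc1`) gives 91000 nM and compound 2 (`CCc1ccc(Nc2nc3ccccc3cc2-c2ccccc2)cc1`) gives 73000 nM as its reading. Compound 2 stands within the scatter of compound 1, so these two numbers cannot be put in order. The next compound to be read is compound 3 (`COc1cccc(Nc2nc3ccccc3cc2-c2ccccc2)c1`), which carries 3-methoxyphenyl in place of 4-ethylphenyl on a nitrogen on an aromatic ring. Among the compounds with values here, no two measured compounds differ in one place only, so the data give no direct measure of this exchange. Any expectation in this assay therefore rests on just two readings, compound 2 at 73000 nM and compound 1 at 91000 nM, which agree within the scatter. Going by these compounds, no step beyond the scatter is expected, and the direction stays open. The estimated change is a 1.0-fold lower number from compound 2 to compound 3 (0.02 log units; within the scatter), a size expected to stay within the scatter. For compound 3 the expected value is 70000 nM, with an estimated range from 32000 nM to 150000 nM as its limits.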

Compound 3, half-maximal inhibitory concentration: 119000 nM
Estimate against measurement, compound 3: 1.7-fold (0.23 log units) below; low and high end bracket the measured number.
By their numbers in this assay, from the lowest: compounds 2, 1 and 3 (each within the scatter of the next).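

In this assay, within the data shown here, the exchange of 4-ethylphenyl for 3-methoxyphenyl on a nitrogen on an aromatic ring gives the first direct reading of a change at this position: a 1.6-fold higher number from compound 2 to compound 3 (0.21 log units; within the scatter). The two groups have the same count of 8 heavy atoms, while 3-methoxyphenyl has 1 hydrogen-bond acceptor and 4-ethylphenyl has 0, and this exchange does not separate the two readings in this assay. Nothing measured on these compounds offers an explanation for the reading or ties it to either group.

Two groups at this position cannot show whether a different kind of group, such as an amine or a carboxylic acid within the substituent on this nitrogen, or a longer chain in place of the ethyl, would give a step beyond the scatter. Among these compounds, the part of the core that sets compound 1 apart also stays open: compound 1 differs from compound 2 and from compound 3 in more than one place, and no single-place step isolates that difference.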